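The source may hold more compounds than are shown below. What is called first, only, known or untested is meant among the compounds shown, and "the series" means these compounds.

Measured compounds:
Compound 1 `Cc1ccnc(/C(N)=N/NC(=S)N2CCCC2)c1` gives 57.7% in a functional assay on MCF7 cells (Homo sapiens) for cytotoxicity, read by MTT assay, with a stated time of 72 h, tested at 3 uM; a higher number here means more inhibition of growth at the concentration tested, a lower number less inhibition of growth.
Compound 2 `Cc1cccc(/C(N)=N/NC(=S)N2CCCCC2)n1` gives 27.1% in this assay.
Compound 3 `N/C(=N\NC(=S)N1CCN(c2ccccn2)CC1)c1ccc(F)cn1` gives 27.1% in this assay.

Compound 3 stands level with compound 2 at the digits shown, and together they are the lowest of the three numbers; compound 1 lies higher by an amount beyond the scatter. Compound 4 `Cc1ccnc(/C(N)=N/NC(=S)N2CCN(c3ccccn3)CC2)c1` differs from compound 3 in one place: 4-methylpyridin-2-yl in place of 5-fluoropyridin-2-yl on a carbon with a double bond to nitrogen. For the measured compounds named here, no pair of measured compounds shares this exact change, so its size has not been seen directly. Compound 1 also carries 4-methylpyridin-2-yl and gives the highest of the three numbers, but it differs from compound 4 in other places too, so only a modest rise is expected in this assay, with a wide range. The step of a number 12.9 percentage points higher from compound 3 to compound 4 (beyond the scatter) is expected to be upward but uncertain. Compound 4 is expected to give 40% in this assay, between 20% and 62%.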

Compound 4, percent growth inhibition at one concentration: 32.8%
For compound 4 the middle estimate is 7.2 percentage points above the measured one, and the stated range covers the measured number.
By their numbers in this assay, from the lowest: compounds 2, 3 and 4 (each within the scatter of the next); then compound 1.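

In this assay, for the compounds shown here, the exchange of 5-fluoropyridin-2-yl for 4-methylpyridin-2-yl on a carbon with a double bond to nitrogen gives a number 5.7 percentage points higher from compound 3 to compound 4 (within the scatter) and is the first direct reading of this change. At this position, with the rest of the molecule held constant, the two groups are not told apart. Nothing shown accounts for this result.

On these data alone, what stays open is whether an unsubstituted pyridin-2-yl or a phenyl at this place would separate from these two groups, and whether the same exchange gives a similar step with a pyrrolidine-bearing thiocarbonyl end.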